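Swapping an Aryl Group on a Tolerant Core

A few compounds are considered here, and "the series" means these few. Any claim that something is new, unique, unknown or untested is made for them only; others in the source may bear on it.

Compound 1 `COc1cccc(-c2nc(N)c(Oc3ccccc3OC)c(Cl)n2)c1` gives 14000 nM in a toxicity assay on HaCaT cells (Homo sapiens) for cytotoxicity, read by CCK-8 assay, with a stated time of 24 h; a lower number here means that less compound is tolerated, a higher number that more compound is tolerated.
Compound 2 `COc1ccccc1Oc1c(N)nc(-c2ccccc2F)nc1Cl` gives only a limit of the assay, > 80000 nM in this assay.
Compound 3 `COc1cccc(-c2nc(N)c(Oc3ccccc3OC)c(OCCO)n2)c1` gives 12700 nM in this assay.

Between compound 1 and compound 2 the change is 2-fluorophenyl in place of 3-methoxyphenyl on an aromatic carbon, and it gave an at least 5.7-fold higher number from compound 1 to compound 2 (0.75 log units; beyond the scatter). Compound 2 sits at the limit of > 80000 nM in this assay, at which 1 of the 3 values shown sits. The cores of compound 1 and compound 3 differ by 2-hydroxyethoxy in place of chloro on an aromatic carbon, a change that gave a 1.1-fold lower number from compound 1 to compound 3 (0.04 log units; within the scatter). Compound 4 `COc1ccccc1Oc1c(N)nc(-c2ccccc2F)nc1OCCO` carries the same kind of change as compound 2, (2-fluorophenyl in place of 3-methoxyphenyl on an aromatic carbon); here the place is meta to a 2-hydroxyethoxy group and para to a 2-methoxyphenoxy group, where before it was meta to a chloro group and para to a group of 9 heavy atoms. The step from compound 3 to compound 4 is expected to be a 5.5-fold higher number from compound 3 to compound 4 (0.74 log units; beyond the scatter), resting on an at least 5.7-fold higher number from compound 1 to compound 2 (0.75 log units; beyond the scatter), since the core change a 1.1-fold lower number from compound 1 to compound 3 (0.04 log units; within the scatter) left the value essentially in place. Compound 4 is therefore estimated at 70000 nM, quite possibly reported only as a limit, within a range from 30000 nM to 200000 nM.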

Compound 4, half-maximal cytotoxic concentration: 39500 nM
Compound 4: middle estimate off by 1.8-fold (0.25 log units), on the high side, and the stated range covers the measured number.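

The change to 2-fluorophenyl gave a 3.1-fold higher number from compound 3 to compound 4 (0.49 log units; beyond the scatter), so the direction seen on the core of compound 1 also holds on the core of compound 3. This does not show that the size of the step carries over, since compound 2 stands at a limit of the assay and not at a number: the same change on two cores in this assay, an at least 5.7-fold higher number (0.75 log units; beyond the scatter) from compound 1 to compound 2 and a 3.1-fold higher number (0.49 log units; beyond the scatter) from compound 3 to compound 4; the limit leaves it open whether they differ. The change to 2-hydroxyethoxy gave an at least 2.0-fold lower number from compound 2 to compound 4 (0.30 log units; that floor lies within the scatter), and this step too rests on that limit, so it cannot be matched against the same change on the other core: the same change on two cores in this assay, a 1.1-fold lower number (0.04 log units; within the scatter) from compound 1 to compound 3 and an at least 2.0-fold lower number (0.30 log units; that floor lies within the scatter) from compound 2 to compound 4; the limit leaves it open whether they differ.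

The compounds shown leave open whether the aryl change behaves the same way when an amine or a carboxylic acid takes the place of the chloro or 2-hydroxyethoxy group.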